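Allyloxy to methoxy: expected cytotoxicity for compound 4

The source may hold more compounds than are shown below. What is called first, only, known or untested is meant among the compounds shown, and "the series" means these compounds.

Of the compounds shown here, three have been measured in an ADME assay on PC-3 cells (Homo sapiens) for cytotoxicity, read by WST assay, tested at 100 uM; on this read-out higher numbers stand for more inhibition at the one concentration tested (going by the name of the read-out) and lower numbers for less inhibition. Compound 1 `C=CCOc1cccc(NC(=O)C2CCCN(C(=O)c3cc(C(F)(F)F)cc(C(F)(F)F)c3)C2)c1` gives 0%. Compound 2 `O=C(Nc1ccc(Cl)cc1)C1CCCN(C(=O)c2cccc(-c3nccs3)c2)C1` gives 32%, and compound 3 `CS(=O)(=O)Nc1cccc(C(=O)N2CCCC(C(=O)Nc3ccc(Cl)cc3)C2)c1` gives 3%. Among the compounds with values here, the only single-point step among them runs between compound 2 and compound 3, where a number 29 percentage points lower from compound 2 to compound 3 (beyond the scatter). Within the data shown here, compound 1 and compound 3 sit within the scatter of each other, while compound 2 lies beyond the scatter above both; compound 1 and compound 2 differ in more than one place, so no single step joins them.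

Compound 4 `COc1cccc(NC(=O)C2CCCN(C(=O)c3cc(C(F)(F)F)cc(C(F)(F)F)c3)C2)c1` differs from compound 1 in one place: hydrogen in place of vinyl on a saturated chain carbon bound to an oxygen on an aromatic ring. Among the measured compounds shown here, no measured step touches this part of the molecule; the one step in hand changes a substituent on the other aromatic ring and so does not bear on it. With compound 1 at 0% and nothing to suggest movement, the expectation is a step of a number 2 percentage points higher from compound 1 to compound 4 (within the scatter), none beyond the scatter. Compound 4 is therefore estimated at 2%, within -8% to 15%.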

Compound 4, a percentage reported as inhibition, at one concentration (the size of the read-out at that concentration, not a potency): 0%
Beside the measured number, compound 4's estimate is 2 percentage points above it; the measured number falls inside the stated range.
By their numbers in this assay, from the lowest: compounds 1, 4 and 3 (each within the scatter of the next); then compound 2.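

In this assay, within the data shown here, allyloxy to methoxy gives the first reading at this position, with no change at the digits printed from compound 1 to compound 4 (within the scatter). Replacing vinyl with hydrogen on a saturated chain carbon bound to an oxygen on an aromatic ring therefore does not separate these two compounds, so the double bond outside aromatic rings is not needed to keep this number where it stands in compound 1. This holds only for the core of compound 1, and no measurement in hand addresses why the two compounds read alike.

As far as these compounds go, whether a longer chain such as butyl, or a chain ending in an amine or a carboxylic acid, would leave the number in place remains open. From the compounds shown here alone, it is also open whether allyloxy to methoxy would read the same way on a core with a higher starting number.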